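The source may hold more compounds than are shown below. What is called first, only, known or untested is meant among the compounds shown, and "the series" means these compounds.

Compound 2 `COc1cc(-c2ccnc3cc(-c4ccccc4)nn23)cc(OC)c1OC` was run in a functional assay on HCT-116 cells (Homo sapiens) for inhibition, read by CCK-8 assay, with a stated time of 48 h (on this read-out higher numbers stand for weaker inhibition and lower numbers for stronger inhibition), where compound 2 gives 3880 nM. Among the three numbers known so far this is the second highest. Its nearest neighbour is compound 3 `COc1cc(-c2ccnc3cc(-c4cn(C(=O)OC(C)(C)C)c5ccccc45)nn23)cc(OC)c1OC`, which in this assay gives 5720 nM, a gap within the scatter; the furthest is compound 1 `COc1cc(-c2ccnc3cc(-c4cn(CO)c5ccccc45)nn23)cc(OC)c1OC`, which in this assay gives 128 nM. Among the compounds with values here, the only step between measured compounds that differ in one place is a 45-fold higher number from compound 1 to compound 3 (1.65 log units; beyond the scatter), tert-butoxycarbonyl in place of hydroxymethyl on an aromatic nitrogen. Compound 4 `COc1ccc(-c2cc3nccc(-c4cc(OC)c(OC)c(OC)c4)n3n2)cc1` differs from compound 2 by methoxy in place of hydrogen on an aromatic carbon, on an aromatic carbon of a six-membered aromatic ring of carbon only, para to a large group. Within the data shown here, no measured step concerns a methoxy entering in place of hydrogen, and the step between compound 1 and compound 3 sits on another part of the molecule, so it offers no direct guide here. Compound 4 is therefore expected to give in this assay about 2500 nM, within 800 nM to 8000 nM. That expected step, a 1.6-fold lower number from compound 2 to compound 4 (0.19 log units; within the scatter), would stay within the scatter.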

Compound 4, half-maximal inhibitory concentration: 404 nM
Compound 4: the middle estimate sits 6.2-fold (0.79 log units) above what was measured, and the stated range ends above it.
By their numbers in this assay, from the lowest: compound 1; then compound 4; then compounds 2 and 3 (each within the scatter of the next).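

In this assay, the change from phenyl to 4-methoxyphenyl gives a 9.6-fold lower number from compound 2 to compound 4 (0.98 log units; beyond the scatter), so a methoxy in place of hydrogen on this aromatic carbon, para to a large group, moves the number beyond the scatter. Within the data shown here, the only earlier step, a 45-fold higher number from compound 1 to compound 3 (1.65 log units; beyond the scatter), concerned a group on an aromatic nitrogen and showed nothing about this six-membered ring of carbon only. Nothing available here accounts for the size of the new step.

The compounds shown leave open whether the shift belongs to methoxy itself or would also follow from a hydroxyl, a fluorine or a dimethylamino group at this place. They also leave open whether a longer chain such as ethoxy or butoxy would keep it, and whether the same methoxy would act alike on the ring carrying the hydroxymethyl group of compound 1.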